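Swapping the amide side chain toward a naphthyloxy group

This account rests on a few compounds, and the source may have more. Where it says the series, first, only, none or still open, it means among the compounds named here.

Measured compounds:
- compound 1 `COc1ccc(OCC(=O)N2CCN(c3ccc(C(F)(F)F)cc3[C@@H](N)CC(C)C)CC2)cc1`: 3800 nM
- compound 2 `CC(C)C[C@H](N)c1cc(C(F)(F)F)ccc1N1CCN(C(=O)C(C)Cc2ccc(Cl)cc2O)CC1`: 36 nM

Of the compounds shown here, two sharing one core have been measured in an assay on HEK293 cells for displacement of a labelled ligand from Melanocortin receptor 4 (Homo sapiens); a higher number here means a weaker inhibitor, a lower number a stronger inhibitor. Compound 1 gives 3800 nM, and compound 2 gives 36 nM. Within the data shown here, compound 2 therefore stands at the lowest number of the two; the only other value, for compound 1, lies at a much higher number, the change being a 110-fold lower number from compound 1 to compound 2 (2.02 log units; beyond the scatter). That single step tells that exchanging the aryloxymethyl group on the carbonyl carbon for the chloro-hydroxybenzyl ethyl group sharply strengthens binding.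

Compound 3 `CC(C)C[C@H](N)c1cc(C(F)(F)F)ccc1N1CCN(C(=O)COc2cccc3ccccc23)CC1` has not yet been measured in this assay. It differs from compound 2 as follows: ((naphthalen-1-yl)oxy)methyl in place of 1-(4-chloro-2-hydroxybenzyl)ethyl on a carbonyl carbon. The group that enters resembles the group of compound 1 more than that of compound 2, since both are aryloxymethyl groups on the same carbonyl carbon. Because the earlier exchange produced a 110-fold lower number from compound 1 to compound 2 (2.02 log units; beyond the scatter), partly undoing it is expected to move the number back upward, by an estimated 28-fold higher number from compound 2 to compound 3 (1.44 log units; beyond the scatter). A weaker binder than compound 2 is expected, though the larger second ring leaves the size of the loss uncertain. The estimate for compound 3 is 1000 nM, within a range of 200 nM to 5000 nM.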

Compound 3, inhibition constant: 2600 nM
Beside the measured number, compound 3's estimate is 2.6-fold (0.41 log units) below it, within the range that was stated.
By their numbers in this assay, from the lowest: compound 2; then compounds 3 and 1 (each within the scatter of the next).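

In this assay, putting ((naphthalen-1-yl)oxy)methyl in place of 1-(4-chloro-2-hydroxybenzyl)ethyl on the carbonyl carbon gives a 72-fold higher number from compound 2 to compound 3 (1.86 log units; beyond the scatter), so a second aryloxymethyl group now shows a large loss at this position. Within that aryloxymethyl pair, the exchange of 4-methoxyphenyl for naphthalen-1-yl on the oxygen gives a 1.5-fold lower number from compound 1 to compound 3 (0.16 log units; within the scatter), which means that a second aromatic ring in this group makes no readable difference and that these two compounds cannot be ranked. Nothing measured here explains the large gap between the two kinds of side chain.

On these data alone, what remains open is which feature of the 1-(4-chloro-2-hydroxybenzyl)ethyl group goes with the stronger binding: the hydroxy group, the chlorine, the branching methyl or the all-carbon link to the ring. A plain 1-benzylethyl group, or a version carrying an amine where the hydroxy group stands, would help to separate these features, and an aryloxymethyl group with a hydroxy group and a chlorine on its ring would show whether those two substituents matter without the all-carbon link.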